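From pyrrolidin-1-yl to 4-(pyridin-2-yl)piperazin-1-yl

A few compounds are considered here, and "the series" means these few. Any claim that something is new, unique, unknown or untested is made for them only; others in the source may bear on it.

Measured compounds:
compound 1 `O=C(Nc1ccc(Cl)cc1)Nc1nc(Sc2c[nH]c3ccccc23)cc(N2CCCC2)n1`, 10400 nM
compound 2 `O=C(Nc1ccccc1)Nc1nc(Sc2c[nH]c3ccccc23)cc(N2CCCC2)n1`, 14900 nM

In a functional assay on PC-3 cells (Homo sapiens) for inhibition, with a stated time of 72 h (a higher number here means a weaker inhibitor, a lower number a stronger inhibitor), compound 1 gives 10400 nM. In this assay, within the data shown here, compound 2 gives 14900 nM, the highest of the two numbers, though the only step to it, a 1.4-fold higher number from compound 1 to compound 2 (0.16 log units; within the scatter), stays within the scatter, so the two compounds cannot be ranked.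

Compound 3 `O=C(Nc1ccccc1)Nc1nc(Sc2c[nH]c3ccccc23)cc(N2CCN(c3ccccn3)CC2)n1` differs from compound 2 at another place: 4-(pyridin-2-yl)piperazin-1-yl in place of pyrrolidin-1-yl on an aromatic carbon. Among the measured compounds shown here, the one measured step concerns the chloro on the phenyl ring, not this position, so no measured step bears directly on the change. With nothing to build on beyond the two numbers, the expected step of a 1.2-fold lower number from compound 2 to compound 3 (0.09 log units; within the scatter) is set at no change beyond the scatter, with a wide range to reflect the lack of a comparison. Compound 3 is therefore estimated at 12000 nM, within 3000 nM to 45000 nM.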

Compound 3, half-maximal inhibitory concentration: 21600 nM
Beside the measured number, compound 3's estimate is 1.8-fold (0.26 log units) below it; measured number inside the range.
By their numbers in this assay, from the lowest: compounds 1, 2 and 3 (each within the scatter of the next, the first and the last beyond it).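

Among these compounds, the earlier compounds spoke only to the chloro on the phenyl ring; compound 3 is the first to test the place on the ring opposite the ring nitrogen. Here a group of 12 heavy atoms with two rings, 4-(pyridin-2-yl)piperazin-1-yl, stands where pyrrolidin-1-yl, with 5 heavy atoms and one ring, stood, and in this assay the result is a 1.4-fold higher number from compound 2 to compound 3 (0.16 log units; within the scatter), so this exchange gives no change that can be told from the scatter. No evidence at hand bears on this result.

From the compounds shown here alone, whether a free amine such as piperazin-1-yl, or morpholin-4-yl, a carboxylic acid or a longer chain at this place would move the number beyond the scatter stays open. Also open, going by these compounds, is whether the chloro on the phenyl ring would give a different step with 4-(pyridin-2-yl)piperazin-1-yl in place.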